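A few compounds are considered here, and "the series" means these few. Any claim that something is new, unique, unknown or untested is made for them only; others in the source may bear on it.

Working notes on the series. Three compounds have numbers: compound 1 `CCCNC(=S)Nc1cccc(OCCCCCc2ccccc2)c1`, compound 2 `S=C(Nc1ccccc1)Nc1cccc(OCCCCCc2ccccc2)c1` and compound 3 `NC(=S)Nc1cccc(OCCCCCOc2ccc(F)cc2)c1`. In an ADME assay on Ava5 cells (Homo sapiens) for cytotoxicity (on this read-out lower numbers stand for higher toxicity in this test and higher numbers for lower toxicity in this test), compound 1 gives 32000 nM, compound 2 gives 35000 nM and compound 3 gives 5000 nM, the lowest of the three numbers, both other compounds sitting beyond the scatter above it. Going by the values given here, the one step between measured neighbours, a 1.1-fold higher number from compound 1 to compound 2 (0.04 log units; within the scatter), is phenyl in place of propyl on an amide-type nitrogen and stays within the scatter. Compound 4 `NC(=S)Nc1cccc(OCCCCCOc2ccc(N3CCCC3)cc2)c1` differs from compound 3 by pyrrolidin-1-yl in place of fluoro on an aromatic carbon. Among the compounds with values here, no measured step touches this end of the chain, so the single step within the scatter is the only guide. For compound 4 in this assay no change beyond the scatter is expected, no change at the digits printed from compound 3 to compound 4 (within the scatter), giving an estimate of 5000 nM with a range from 1500 nM to 16000 nM.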

Compound 4, half-maximal cytotoxic concentration: 16000 nM
For compound 4 the middle estimate is 3.2-fold (0.51 log units) below the measured one; the measured number falls inside the stated range.
By their numbers in this assay, from the lowest: compound 3; then compounds 4, 1 and 2 (each within the scatter of the next, the first and the last beyond it).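

Going by these compounds alone, at this aromatic carbon, para to a large group, pyrrolidin-1-yl in place of fluoro gives a 3.2-fold higher number from compound 3 to compound 4 (0.51 log units; beyond the scatter) in this assay and is the first step between measured neighbours to lie beyond the scatter. This end of the chain therefore registers in this read-out, unlike the earlier change on the amide-type nitrogen, which stayed within the scatter. No evidence at hand bears on what lies behind this step.

The compounds shown leave open whether a morpholine, a piperidine or a dimethylamino group on this carbon would give a step of similar size. They also leave open whether a longer chain would alter this step.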